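The compounds below may be only part of what the source reports. "The series", "measured", "known", "first", "only" and "open" are said of these compounds alone.

The measured compounds:
Compound 1 `Cc1cccc(-n2nncc2CN2C(=O)C3(C(C#N)=C(N)Oc4c3c3nc5ccccc5nc3c3ccccc43)c3ccccc32)c1`, in an ADME assay on HUVEC cells (Homo sapiens) for antiproliferative activity, read by MTT assay, with a stated time of 48 h (on this read-out lower numbers stand for stronger inhibition and higher numbers for weaker inhibition), reaches only the limit of the assay, > 50000 nM.
Compound 2 `N#CC1=C(N)Oc2c(c3nc4ccccc4nc3c3ccccc23)C12C(=O)N(Cc1cnnn1-c1ccccc1Cl)c1ccccc12`, in this assay, likewise reaches only the limit, > 50000 nM.
Compound 3 `N#CC1=C(N)Oc2c(c3nc4ccccc4nc3c3ccccc23)C12C(=O)N(Cc1cnnn1-c1cccc(Br)c1)c1ccccc12`, in this assay, again gives no number but the limit, > 50000 nM.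

Compound 3 therefore stands where every measured compound of this set stands: at the limit, with no number of its own to place it above or below its two neighbours. This is summed up by the limit of > 50000 nM in this assay, at which 3 of the 3 values shown sit. The change that leads on from it is 2-methoxyphenyl in place of 3-bromophenyl on an aromatic nitrogen, giving compound 4 `COc1ccccc1-n1nncc1CN1C(=O)C2(C(C#N)=C(N)Oc3c2c2nc4ccccc4nc2c2ccccc32)c2ccccc21`.

Among the compounds with values here, three measured steps touch the same position on the aromatic nitrogen: a step that the two limits leave unreadable from compound 1 to compound 2, a step that the two limits leave unreadable from compound 1 to compound 3 and a step that the two limits leave unreadable from compound 2 to compound 3. None of them can be read, since both ends of each sit at the limit. The exchanges of a methyl, a chloro and a bromo substituent on that phenyl ring have thus left no measurable trace in this assay, and the data give no basis for expecting the methoxy substituent to behave differently. Compound 4 is accordingly expected to remain at the limit, with an estimated step of a number no higher from compound 3 to compound 4 (the limit leaves the size open). The estimate for compound 4 in this assay is 50000 nM, within a range from 20000 nM to 200000 nM.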

Compound 4, half-maximal inhibitory concentration: > 50000 nM
Compound 4: no number, only a limit; the forecaster's own chance of this, stated with the estimate: 85%; the middle value sits exactly at the limit.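

Compound 4 also gives only a limit, so none of its steps from compound 1, compound 2 or compound 3 can be read, since all four compounds sit at the same limit: the limit of > 50000 nM in this assay, at which 4 of the 4 values shown sit.

The compounds shown leave open how strongly any of them acts in this assay, and whether the substituent on the phenyl ring makes any difference there.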